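Dropping a Methoxy Group on the Outer Ring

The source may report more compounds than this note shows. Statements on the series, on what has been measured and on what is new or still open speak of the compounds shown alone.

Measured compounds in a physicochemical assay for acid dissociation:
compound 1, `COc1cccc(CNCCCNc2ccnc3cc(Oc4ccc(Cl)cc4)ccc23)c1O`, gives 9.28
compound 2, `COc1cccc(CNCCCNc2ccnc3cc(Cc4ccccc4)ccc23)c1O`, gives 9.47
compound 3, `COc1cccc(Oc2ccc3c(NCCCNCc4cccc(OC)c4O)ccnc3c2)c1`, gives 9.28

Compound 3 stands level with compound 1 and, together with it, at the lowest of the three numbers; compound 2 lies apart from it only by a number 0.19 log units lower from compound 2 to compound 3 (within the scatter), which is within the scatter. All three compounds share the same core and differ only in the group hanging from the outer aromatic carbon.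

Compound 4, `COc1cccc(CNCCCNc2ccnc3cc(Oc4ccccc4)ccc23)c1O`, follows from compound 3 by a small change: hydrogen in place of methoxy on an aromatic carbon.

Within the data shown here, two measured steps bear on this. Replacing the whole outer aryl group on the oxygen gave no change at the digits printed from compound 1 to compound 3 (within the scatter), and exchanging the oxygen-linked aryl for a benzyl group gave a number 0.19 log units higher from compound 1 to compound 2 (within the scatter). Neither change at this distant position moved the number beyond the scatter, so removing one methoxy group there is expected to do the same. The expected step is therefore a number 0.02 log units higher from compound 3 to compound 4 (within the scatter).

Compound 4 is expected to give 9.3, within the range 9 to 9.6.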

Compound 4, acid dissociation constant: 9.28
Compound 4: the middle estimate sits 0.02 log units above what was measured, within the range that was stated.
By their numbers in this assay, from the lowest: compounds 1, 3, 4 and 2 (each within the scatter of the next).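

In this assay, taking the methoxy group off the outer ring gives no change at the digits printed from compound 3 to compound 4 (within the scatter), and taking the chloro group off gives no change at the digits printed from compound 1 to compound 4 (within the scatter), so compound 4, with its bare phenoxy group, shows that neither of these two substituents on that ring moves the number beyond the scatter. Compound 4 also allows a comparison of the linking groups without any substituent on the outer ring: phenoxy in place of benzyl gives a number 0.19 log units lower from compound 2 to compound 4 (within the scatter), which is also within the scatter. Nothing available explains why the number holds steady across these changes.

Only methoxy and chloro have been compared with hydrogen on the outer ring here. Going by these compounds, whether an amine or a carboxylic acid on that ring, or a longer chain in the shared core, would also leave the number in place stays open.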